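The source may report more compounds than this note shows. Statements on the series, on what has been measured and on what is new or still open speak of the compounds shown alone.

Three compounds are built on the same core, differing only in the aryl group on the ether oxygen and in one substituent on the aromatic ring of the core. Compound 1, `Cc1ccccc1OCC(=O)Nc1ccc(Cl)cc1C(N)=O`, is the starting point. In a functional assay on K562 cells (Homo sapiens) for inhibition, read by trypan blue exclusion, with a stated time of 24 h, tested at 10 uM (on this read-out lower numbers stand for less inhibition of growth and higher numbers for more inhibition of growth at the one concentration tested), compound 1 gives 75.9%. Compound 2, `Cc1ccc(OCC(=O)Nc2ccc(Cl)cc2C(N)=O)cc1`, differs from compound 1 in one place, (4-methylphenyl in place of 2-methylphenyl on an oxygen on a saturated carbon). In this assay compound 2 gives 24.1%, a step of a number 51.8 percentage points lower from compound 1 to compound 2 (beyond the scatter). Compound 3, `COc1ccc(NC(=O)COc2ccccc2C)c(C(N)=O)c1`, keeps the 2-methylphenyl group of compound 1 but carries a changed core, (methoxy in place of chloro on an aromatic carbon). In this assay compound 3 gives 40.1%, the second highest of the three numbers; the step is a number 35.8 percentage points lower from compound 1 to compound 3 (beyond the scatter), and against compound 2 the number of compound 3 is the higher of the two.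

Compound 4, `COc1ccc(NC(=O)COc2ccc(C)cc2)c(C(N)=O)c1`, is not yet measured. It differs from compound 3 in one place, (4-methylphenyl in place of 2-methylphenyl on an oxygen on a saturated carbon). The place of this change is, word for word, the same as in the change from compound 1 to compound 2, so it is the same change. That earlier change gave a number 51.8 percentage points lower from compound 1 to compound 2 (beyond the scatter). The read-out has a floor. From a starting point as low as that of compound 3 a drop of equal size cannot follow, so the expected step is smaller in size though in the same direction. Compound 4 is expected to show a step of a number 30.1 percentage points lower from compound 3 to compound 4 (beyond the scatter). Compound 4 is estimated to give 10% in this assay, within 0% to 28%.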

Compound 4, percent growth inhibition at one concentration: 48.1%
Compound 4: middle estimate off by 38.1 percentage points, on the low side, outside the stated range (above it).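

In this assay, the exchange of 2-methylphenyl for 4-methylphenyl does not carry over from the core of compound 1 to the core of compound 3, where it gives a number 8 percentage points higher from compound 3 to compound 4 (within the scatter), so that compound 3 and compound 4 cannot be told apart, and the two results for this change differ: the same change on two cores in this assay, a number 51.8 percentage points lower (beyond the scatter) from compound 1 to compound 2 and a number 8 percentage points higher (within the scatter) from compound 3 to compound 4, 59.8 percentage points apart, beyond the scatter of two such steps

The exchange of chloro for methoxy does not carry over either, since with 4-methylphenyl in place it gives a number 24 percentage points higher from compound 2 to compound 4 (beyond the scatter), opposite in direction to the step seen with 2-methylphenyl: the same change on two cores in this assay, a number 35.8 percentage points lower (beyond the scatter) from compound 1 to compound 3 and a number 24 percentage points higher (beyond the scatter) from compound 2 to compound 4, 59.8 percentage points apart, beyond the scatter of two such steps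

These four compounds show that, in this set, the outcome of each change depends on the group held at the other place, but they do not show why, and with one square of compounds at a single concentration they do not show whether this would hold for other groups or on other cores.

The compounds shown leave open how the phenyl ring on the ether oxygen would fare with no methyl group at all, or with an ethyl group or a carboxylic acid in place of the methyl. They also leave open what an amine or a nitrile would do in place of the chloro or methoxy on the core.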